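Removing the chloro from compound 2: expected solubility

The compounds below may be only part of what the source reports. "The series", "measured", "known", "first", "only" and "open" are said of these compounds alone.

Measured so far in a physicochemical assay for solubility, read by HPLC, in simulated intestinal fluid, with a stated time of 16 h, at pH 6.5; a lower number here means a less soluble compound, a higher number a more soluble compound:
compound 1, `CNC(=O)c1cc(C(=O)N[C@H]2[C@@H]3C[C@H](O)C[C@@H]32)n([C@@H](C)c2cccc(Cl)c2)n1`, 327 ug/mL
compound 2, `CNC(=O)c1cc(C(=O)N[C@H]2CC[C@H](O)CC2)n([C@@H](C)c2cccc(Cl)c2)n1`, 196 ug/mL
compound 3, `CNC(=O)c1cc(C(=O)N[C@H]2CC[C@H](O)CC2)c([C@@H](C)c2ccccc2Cl)o1`, a value at the limit of the assay, > 1000 ug/mL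

Compound 2 has the lowest of the two numbers; the step of a 1.7-fold lower number from compound 1 to compound 2 (0.22 log units; within the scatter) changes only the ring on the amide nitrogen. Compound 3 sits at the limit of this assay (the limit of > 1000 ug/mL in this assay, at which 1 of the 3 values shown sits).

Compound 4, `CNC(=O)c1cc(C(=O)N[C@H]2CC[C@H](O)CC2)n([C@@H](C)c2ccccc2)n1`, differs from compound 2 by hydrogen in place of chloro on an aromatic carbon. For the measured compounds named here, no measured step touches this position, so no step bears directly on it. Compound 4 is estimated at 350 ug/mL, between 150 ug/mL and 800 ug/mL. That is an expected step of a 1.8-fold higher number from compound 2 to compound 4 (0.25 log units; within the scatter), possibly within the scatter.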

Compound 4, solubility: 366 ug/mL
Compound 4: the middle estimate sits 1.0-fold (0.02 log units) below what was measured; low and high end bracket the measured number.
By their numbers in this assay, from the lowest: compounds 2, 1 and 4 (each within the scatter of the next). At a limit, above all of these: compound 3.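

Hydrogen in place of chloro on this aromatic carbon, the 3-chlorophenyl to phenyl difference, gives a 1.9-fold higher number from compound 2 to compound 4 (0.27 log units; within the scatter) in this assay. For the compounds shown here, all the earlier compounds carry a chlorine on that aromatic ring, so this pair is the first reading without one, and it shows no step beyond the scatter. Nothing at hand gives a measured reason for this step.

As far as these compounds go, whether a fluoro, a methoxy or an aminomethyl group on that aromatic carbon would read like hydrogen or chloro stays open. So does whether the same difference reads alike with the ring on the amide nitrogen of compound 1.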